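Pyrazole series: amide to urea at the anilide carbonyl

This account rests on a few compounds, and the source may have more. Where it says the series, first, only, none or still open, it means among the compounds named here.

Measured so far:
compound 1 `COc1cc(-c2nn(-c3cccc(NC(=O)c4cccc(C(F)(F)F)c4)c3)cc2-c2ccncc2)ccc1Cl` — 2280 nM
compound 2 `O=C(Nc1cccc(-n2cc(-c3ccncc3)c(-c3ccc(Cl)c(O)c3)n2)c1)Nc1cc(C(F)(F)F)cc(C(F)(F)F)c1` — 849 nM

In a functional assay on OVCAR-4 cells (Homo sapiens) for inhibition, read by sulforhodamine B assay, with a stated time of 48 h (on this read-out higher numbers stand for weaker inhibition of growth and lower numbers for stronger inhibition of growth), compound 1 gives 2280 nM, the higher of the two numbers measured. Compound 2 is not separated from compound 1 by a single change. In this assay, going by the values given here, compound 2 gives 849 nM, a gap from compound 1 that goes beyond the scatter; since the two compounds differ in several places, the numbers show only that compound 2 inhibits growth more strongly, not which part of the structure is responsible.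

Compound 3 `COc1cc(-c2nn(-c3cccc(NC(=O)Nc4ccc(Cl)c(Cl)c4)c3)cc2-c2ccncc2)ccc1Cl` has not been measured. It keeps the core of compound 1 and changes only one place: (3,4-dichlorophenyl)amino in place of 3-(trifluoromethyl)phenyl on a carbonyl carbon. Among the compounds with values here, compound 2 also carries a urea, and its lower number gives some ground to expect the step to go toward stronger inhibition, but with no measured single-change step the direction cannot be fixed.

Compound 3 is estimated at 1200 nM in this assay, within a range of 400 nM to 3500 nM; this means an expected step of a 1.9-fold lower number from compound 1 to compound 3 (0.28 log units; within the scatter), modest and of uncertain direction.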

Compound 3, concentration for 50% growth inhibition: 1290 nM
Compound 3: the middle estimate sits 1.1-fold (0.03 log units) below what was measured; low and high end bracket the measured number.
By their numbers in this assay, from the lowest: compounds 2, 3 and 1 (each within the scatter of the next, the first and the last beyond it).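

In this assay, going by these compounds alone, the exchange of 3-(trifluoromethyl)phenyl for (3,4-dichlorophenyl)amino on a carbonyl carbon gives a 1.8-fold lower number from compound 1 to compound 3 (0.25 log units; within the scatter) as the first single-change step. The position therefore accepts the change from (3-(trifluoromethyl)phenyl)carbonyl to (3,4-dichlorophenyl)carbamoyl, with the hydrogen-bond donor that enters and with chlorine replacing trifluoromethyl, without separating the two compounds on this read-out. The step carries the new nitrogen and the new ring substituents together, so it credits neither alone, and nothing measured on these compounds explains the result.

Still open, from the compounds shown here alone, is how the two parts of the change contribute taken one at a time: a urea that keeps 3-(trifluoromethyl)phenyl, or an amide that carries 3,4-dichlorophenyl, would divide the step between them. Also open, going by these compounds, is whether another link on the same carbonyl carbon, such as a carbamate oxygen or a methylene chain in place of the amino nitrogen, would move the number beyond the scatter.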